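From chloro to trifluoromethyl in a three-compound series

This account rests on a few compounds, and the source may have more. Where it says the series, first, only, none or still open, it means among the compounds named here.

Among the compounds with values here, in a functional assay on HeLa cells (Homo sapiens) for antiproliferative activity, read by MTT assay, with a stated time of 24 h (on this read-out lower numbers stand for stronger inhibition and higher numbers for weaker inhibition), compound 1 `Cc1ccc(-c2nn(-c3ccccc3)cc2-c2nc3ccccc3n2S(=O)(=O)c2ccc(F)cc2)cc1` gives 3670 nM and compound 2 `Cc1ccc(-c2nn(-c3ccccc3)cc2-c2nc3ccccc3n2S(=O)(=O)c2ccc(Cl)cc2)cc1` gives 4060 nM, so compound 2 stands level with the only other measured compound. Compound 3 `Cc1ccc(-c2nn(-c3ccccc3)cc2-c2nc3ccccc3n2S(=O)(=O)c2ccc(C(F)(F)F)cc2)cc1` carries trifluoromethyl in place of chloro on an aromatic carbon, para to a large group: trifluoromethyl in place of chloro on an aromatic carbon. Within the data shown here, one measured step bears on this, chloro in place of fluoro, a 1.1-fold higher number from compound 1 to compound 2 (0.04 log units; within the scatter), and it stayed within the scatter. On that single step, no change beyond the scatter is expected in this assay. The estimated step is a 1.1-fold lower number from compound 2 to compound 3 (0.03 log units; within the scatter). For compound 3 the expected value is 3800 nM, with an estimated range of 1900 nM to 7500 nM.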

Compound 3, half-maximal inhibitory concentration: 1520 nM
For compound 3 the middle estimate is 2.5-fold (0.40 log units) above the measured one, and the stated range ends above it.
By their numbers in this assay, from the lowest: compound 3; then compounds 1 and 2 (each within the scatter of the next).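

In this assay, the position on the sulfonyl-bound phenyl ring proved able to move the read-out, which the exchange of fluoro for chloro had not shown. Trifluoromethyl gives a 2.7-fold lower number from compound 2 to compound 3 (0.43 log units; beyond the scatter) and a 2.4-fold lower number from compound 1 to compound 3 (0.38 log units; beyond the scatter), both modest but beyond the scatter. Among these three compounds, fluoro and chloro therefore stand level, and only trifluoromethyl separates from them.

From the compounds shown here alone, whether a methoxy group, an amine or a carboxylic acid at this place would go further remains open. Nothing given here accounts for the gain in inhibition.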